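Exchanging the fused ring on the carbonyl of compound 2

The compounds below may be only part of what the source reports. "The series", "measured", "known", "first", "only" and "open" are said of these compounds alone.

Three compounds have been measured in an assay for inhibition of Nicotinamide phosphoribosyltransferase (Homo sapiens), read by mass spectrometry, with stated times of 15 min and 30 min; a higher number here means a weaker inhibitor, a lower number a stronger inhibitor:

compound 1 `O=C(NCc1ccc(S(=O)(=O)c2ccccc2)cc1)c1cc2ccncc2s1`: 7 nM
compound 2 `O=C(NCc1ccc(S(=O)(=O)c2ccccc2)cc1)c1nc2ccncc2s1`: 210 nM
compound 3 `O=C(NCc1ccc(S(=O)(=O)c2ccccc2)cc1)c1ccc2cnccc2c1`: > 10000 nM, which is a limit of the assay and not a number

Among the two numbers shown, compound 2 has the highest, and the nearest to it is compound 1, at a 30-fold higher number from compound 1 to compound 2 (1.48 log units; beyond the scatter). For the measured compounds named here, the only step measured so far at this position is that one: a group of 9 heavy atoms (6 carbon, 2 nitrogen, 1 sulfur; one five-membered aromatic ring with 2 hetero atoms, one six-membered aromatic ring with 1 hetero atom) replaced a group of 9 heavy atoms (7 carbon, 1 nitrogen, 1 sulfur), and the number went up by a large amount. Compound 3, which carries a different fused ring pair on the same carbonyl, sits at the limit of > 10000 nM in this assay, at which 1 of the 3 values shown sits.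

Compound 4 `O=C(NCc1ccc(S(=O)(=O)c2ccccc2)cc1)c1ccc2nncn2c1` has not yet been measured in this assay. It differs from compound 2 by a group of 9 heavy atoms (6 carbon, 3 nitrogen; one five-membered aromatic ring with 3 hetero atoms, one six-membered aromatic ring with 1 hetero atom) in place of a group of 9 heavy atoms (6 carbon, 2 nitrogen, 1 sulfur; one five-membered aromatic ring with 2 hetero atoms, one six-membered aromatic ring with 1 hetero atom), on a carbonyl carbon. The measured step from compound 1 to compound 2 bears on it only loosely, since it shows that altering the hetero atoms of the fused ring on this carbonyl can move the number a long way; the limit of compound 3 shows that some fused rings here give no measurable number at all. Compound 4 is therefore expected to give a weaker result than compound 2, with a 7.1-fold higher number from compound 2 to compound 4 (0.85 log units; beyond the scatter) as the expected step. The estimate for compound 4 in this assay is 1500 nM, within a range from 250 nM to 9000 nM.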

Compound 4, half-maximal inhibitory concentration: 370 nM
Compound 4: middle estimate off by 4.1-fold (0.61 log units), on the high side, and the stated range covers the measured number.
By their numbers in this assay, from the lowest: compound 1; then compounds 2 and 4 (each within the scatter of the next). At a limit, above all of these: compound 3.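

In this assay, placing the group of 6 carbon and 3 nitrogen on the carbonyl carbon in place of the group of 6 carbon, 2 nitrogen and 1 sulfur gives a 1.8-fold higher number from compound 2 to compound 4 (0.25 log units; within the scatter), so compound 2 and compound 4 cannot be told apart, and a fused group without sulfur can still give a measured number at this position. The gap to the best of the series remains, with a 53-fold higher number from compound 1 to compound 4 (1.72 log units; beyond the scatter), which lies in the same large range as a 30-fold higher number from compound 1 to compound 2 (1.48 log units; beyond the scatter). The absence of sulfur does not settle the outcome, as compound 3 also lacks it and goes against any such reading, its value being a limit of the assay and not a number: the limit of > 10000 nM in this assay, at which 1 of the 4 values shown sits.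

The compounds shown leave open whether any fused group without sulfur can match compound 1, and whether the gap to compound 1 follows the sulfur or the nitrogen atoms, as these groups differ in more than one atom. Also open, going by these compounds, is how a methyl group, an amine or a fluorine on the fused ring of compound 4 would act in this assay.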